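Swapping propoxy for methylsulfanyl in a small compound series

The source may report more compounds than this note shows. Statements on the series, on what has been measured and on what is new or still open speak of the compounds shown alone.

Measured in a functional assay on KB cells (Homo sapiens) for antiproliferative activity, read by sulforhodamine B assay, with a stated time of 3 days; a higher number here means that more compound is needed for the effect, a lower number that less compound is needed:
- Compound 1 `CCC1=C(O)c2c(oc(-c3ccc(CC(C)C)cc3)cc2=O)C(CC)(CC)C1=O`: 29.3 uM
- Compound 2 `CCC1=C(O)c2c(oc(-c3ccc(O)cc3)cc2=O)C(CC)(CC)C1=O`: 20.6 uM
- Compound 3 `CCCOc1ccc(-c2cc(=O)c3c(o2)C(CC)(CC)C(=O)C(CC)=C3O)cc1`: > 50.5 uM

The result for compound 3 is a limit of the assay and not a number. Compound 4 `CCC1=C(O)c2c(oc(-c3ccc(SC)cc3)cc2=O)C(CC)(CC)C1=O` carries methylsulfanyl in place of propoxy on an aromatic carbon, para to a large group (methylsulfanyl in place of propoxy on an aromatic carbon). Three measured steps change this same place: a 1.4-fold lower number from compound 1 to compound 2 (0.15 log units; within the scatter), an at least 1.7-fold higher number from compound 1 to compound 3 (0.23 log units; that floor lies within the scatter) and an at least 2.4-fold higher number from compound 2 to compound 3 (0.38 log units; beyond the scatter). All three are small, and they give no direct measure for methylsulfanyl. With other groups there, compound 1 gives 29.3 uM and compound 2 gives 20.6 uM. In this assay, a modest step to a lower number is therefore expected: an at least 1.6-fold lower number from compound 3 to compound 4 (0.22 log units; that floor lies within the scatter). The estimate for compound 4 is 30 uM, with an expected range of 14 uM to 55 uM.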

Compound 4, concentration for half-maximal effect: > 52.1 uM
Compound 4 ended at the assay's limit; the forecaster's own chance of this, stated with the estimate: 25%; middle value at least 1.7-fold (0.23 log units) from the limit.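

The result for compound 4 is a limit of the assay and not a number, so the step from compound 3 cannot be read, as both compounds end at limits: the limit of > 52.1 uM in this assay, at which 1 of the 4 values shown sits.

Replacing hydroxy with methylsulfanyl gives an at least 2.5-fold higher number from compound 2 to compound 4 (0.40 log units; beyond the scatter), while replacing isobutyl with it gives an at least 1.7-fold higher number from compound 1 to compound 4 (0.24 log units; that floor lies within the scatter). Thus, both propoxy and methylsulfanyl have a step beyond the scatter from hydroxy, whereas isobutyl does not.

From the compounds shown here alone, how propoxy and methylsulfanyl rank against each other stays open. So does what an amine or a carboxylic acid would give at this position.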